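Methyl for Bromo: An Expectation for Compound 4

A few compounds are considered here, and "the series" means these few. Any claim that something is new, unique, unknown or untested is made for them only; others in the source may bear on it.

Of the compounds shown here, three built on one shared core have been tested in a functional assay on cells (T-cell, Mus musculus, strain BALB/c) for inhibition, read by MTT assay, with a stated time of 72 h; a higher number here means a weaker inhibitor, a lower number a stronger inhibitor. Compound 1 `COC(=O)c1c(Br)cccc1OC(=O)COc1cc(O)c2c(=O)cc(-c3ccccc3)oc2c1` gives 41700 nM. Compound 2 `COC(=O)c1c(C)cccc1OC(=O)COc1cc(O)c2c(=O)cc(-c3ccccc3)oc2c1` gives 37200 nM. Compound 3 `COC(=O)c1cc(Br)ccc1OC(=O)COc1cc(O)c2c(=O)cc(-c3ccccc3)oc2c1` gives 780 nM, the lowest of the three numbers; its nearest neighbour is compound 2, seen in a 48-fold lower number from compound 2 to compound 3 (1.68 log units; beyond the scatter), and the furthest is compound 1, seen in a 53-fold lower number from compound 1 to compound 3 (1.73 log units; beyond the scatter). Compound 4 `COC(=O)c1cc(C)ccc1OC(=O)COc1cc(O)c2c(=O)cc(-c3ccccc3)oc2c1` has not yet been measured. It differs from compound 3 by methyl in place of bromo on an aromatic carbon. One measured step shows what this kind of swap has done before on this core: a 1.1-fold lower number from compound 1 to compound 2 (0.05 log units; within the scatter). That step stayed within the scatter, so for compound 4 the same exchange is expected to leave the number close to where compound 3 sits, which amounts to an expected 1.2-fold higher number from compound 3 to compound 4 (0.06 log units; within the scatter). Within the data shown here, compound 4 is therefore estimated at 900 nM, with a range from 300 nM to 2700 nM, the range kept wide since only a single earlier swap informs the guess.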

Compound 4, half-maximal inhibitory concentration: 25700 nM
Beside the measured number, compound 4's estimate is 29-fold (1.46 log units) below it; measured number above the stated range.
By their numbers in this assay, from the lowest: compound 3; then compounds 4, 2 and 1 (each within the scatter of the next).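

At this place on the ring, meta to a methoxycarbonyl group and para to a large group, bromo and methyl are far from interchangeable in this assay: a 33-fold higher number from compound 3 to compound 4 (1.52 log units; beyond the scatter). The same exchange therefore has no single size on this series, and what it does depends on where it is made: the same change on two cores in this assay, a 1.1-fold lower number (0.05 log units; within the scatter) from compound 1 to compound 2 and a 33-fold higher number (1.52 log units; beyond the scatter) from compound 3 to compound 4, 37-fold (1.57 log units) apart, beyond the scatter of two such steps. With methyl at this place, the low number of compound 3 is lost and compound 4 reads like the two compounds with a group at the other place, with a 1.4-fold lower number from compound 2 to compound 4 (0.16 log units; within the scatter) and a 1.6-fold lower number from compound 1 to compound 4 (0.21 log units; within the scatter).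

The compounds shown carry only bromo or methyl on this ring, so it remains open how chloro, a methoxy group or an amine at this place would read. They also cannot tell why bromo gives the low number only at this place.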